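The compounds below may be only part of what the source reports. "The series", "measured", "known", "first", "only" and "open" are said of these compounds alone.

Three compounds have been measured in a functional assay for inhibition, with a stated time of 2 h, tested at 0.0156 g/L; a higher number here means more inhibition at the concentration tested (going by the name of the read-out), a lower number less inhibition:
compound 1, `Cc1sc2c(Nc3cccnc3)cccc2c1C`, gives 48.1%;
compound 2, `COc1ccc(Nc2cccc3c(C)c(C)sc23)cc1OC`, gives 89.3%;
compound 3, `COc1ccc(Nc2cccc3c(C)c(C)sc23)cc1`, gives 92.3%.

Compound 2 has the second highest of these three numbers. The nearest of the others sits a number 3 percentage points higher from compound 2 to compound 3 (within the scatter), a gap within the scatter, while compound 1 lies far lower, beyond the scatter. Compound 4, `COc1cccc(Nc2cccc3c(C)c(C)sc23)c1`, has not yet been measured in this assay. It differs from compound 2 in one place: hydrogen in place of methoxy on an aromatic carbon. Within the data shown here, the one measured step that bears on this is the loss of the other methoxy, a number 3 percentage points higher from compound 2 to compound 3 (within the scatter), which stayed within the scatter. A similar outcome is therefore expected for compound 4, a number 2.3 percentage points lower from compound 2 to compound 4 (within the scatter), with no shift beyond the scatter. Compound 4 is estimated at 87%, with a range from 72% to 96%.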

Compound 4, a percentage reported as inhibition, at one concentration (the size of the read-out at that concentration, not a potency): 56.8%
Compound 4: middle estimate off by 30.2 percentage points, on the high side, outside the stated range (below it).
By their numbers in this assay, from the lowest: compounds 1 and 4 (each within the scatter of the next); then compounds 2 and 3 (each within the scatter of the next).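

In this assay, the same swap of hydrogen for methoxy gives a number 32.5 percentage points lower from compound 2 to compound 4 (beyond the scatter) when the methoxy para to a large group leaves, whereas loss of the other methoxy gives a number 3 percentage points higher from compound 2 to compound 3 (within the scatter) and stays within the scatter. The outcome of this change therefore depends on which methoxy is lost, so one step could not speak for the other. Nothing available explains this difference. On these data alone, whether an ethoxy, a fluorine or an amine at this position would preserve the inhibition seen with methoxy remains open.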